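Opening the ring on the thiocarbonyl carbon

The source may hold more compounds than are shown below. What is called first, only, known or untested is meant among the compounds shown, and "the series" means these compounds.

Of the compounds shown here, three sharing one core have been tested in a functional assay on A-375 cells (Homo sapiens) for antiproliferative activity, read by CCK-8 assay, with a stated time of 72 h, tested at 2 uM; on this read-out higher numbers stand for a stronger effect at the one concentration tested and lower numbers for a weaker effect. Compound 1 `Nc1ccccc1NC(=O)c1ccc(CSC(=S)N2CCN(c3ccc(Cl)cc3)CC2)cc1` gives 32.2%, compound 3 `Nc1ccccc1NC(=O)c1ccc(CSC(=S)N2CCN(Cc3cccnc3)CC2)cc1` gives 31.5%, and compound 2 `CC1CCCCN1C(=S)SCc1ccc(C(=O)Nc2ccccc2N)cc1` gives 42.5%, the highest of the three numbers, standing beyond the scatter above both. For the measured compounds named here, the only measured step, a number 0.7 percentage points lower from compound 1 to compound 3 (within the scatter), touches a different place than the change now considered and lies within the scatter. Compound 4 `CN(Cc1ccncc1)C(=S)SCc1ccc(C(=O)Nc2ccccc2N)cc1` differs from compound 2 by methyl((pyridin-4-yl)methyl)amino in place of 2-methylpiperidin-1-yl on a thiocarbonyl carbon. Going by the values given here, no measured step bears directly on this change; compounds 1 and 3, which also carry an amine in place of the 2-methylpiperidin-1-yl, sit lower than compound 2. A step downward, a number 8.5 percentage points lower from compound 2 to compound 4 (within the scatter), is therefore expected, giving compound 4 an estimated 34% in this assay, between 21% and 47%.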

Compound 4, a percentage reported as inhibition, at one concentration (the size of the read-out at that concentration, not a potency): 31.4%
Compound 4: middle estimate off by 2.6 percentage points, on the high side, within the range that was stated.
By their numbers in this assay, from the lowest: compounds 4, 3 and 1 (each within the scatter of the next); then compound 2.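

Putting methyl((pyridin-4-yl)methyl)amino in place of 2-methylpiperidin-1-yl on the thiocarbonyl carbon gives, in this assay, a number 11.1 percentage points lower from compound 2 to compound 4 (beyond the scatter). For the compounds shown here, this is the first measured step at this position, and it shows that the read-out responds to the group held there. Nothing measured here explains the drop. The change swaps several features at once, so the compounds shown cannot separate the opened ring from the added pyridine ring. As far as these compounds go, whether a plain piperidin-1-yl or a dimethylamino group would sit nearer compound 2 or compound 4 remains open.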